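Nitro in Place of Bromo on the Hydrazone Aryl Ring

The compounds below may be only part of what the source reports. "The series", "measured", "known", "first", "only" and "open" are said of these compounds alone.

Compound 2 `O=C(COc1cccc2ccccc12)N/N=C/c1ccccc1Br` gives 4.81 in a physicochemical assay for lipophilicity, measured as octanol-water partition; a lower number here means a more polar compound, a higher number a more lipophilic compound. Compound 1 `O=C(COc1cccc2ccccc12)N/N=C/c1ccc(Cl)cc1` gives 4.54 in this assay, and the step of a number 0.27 log units higher from compound 1 to compound 2 (within the scatter) lies within the scatter, so the two numbers stand together. Compound 3 `O=C(COc1cccc2ccccc12)N/N=C/c1ccccc1[N+](=O)[O-]` differs from compound 2 by nitro in place of bromo on an aromatic carbon. Within the data shown here, the single measured step exchanges one halogen for another and does not cover bromo against nitro, so no measured step bears on this change. Compound 3 is nevertheless expected to give 3.7, between 3.2 and 4.2. The expected step of a number 1.11 log units lower from compound 2 to compound 3 (beyond the scatter) would reach beyond the scatter.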

Compound 3, partition coefficient: 3.97
The estimate for compound 3 lay 0.27 log units below the measured number, and the stated range covers the measured number.
By their numbers in this assay, from the lowest: compound 3; then compounds 1 and 2 (each within the scatter of the next).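

In this assay, nitro in place of bromo on this aromatic carbon, ortho to a large group, gives a number 0.84 log units lower from compound 2 to compound 3 (beyond the scatter). Among these compounds, the earlier step, which swapped one halogen-bearing phenyl for another, stayed within the scatter, so this is the first sign that a change on this ring can move the number beyond it. No measurement at hand accounts for this step. From the compounds shown here alone, whether an amine or a carboxylic acid on the same carbon would give a similar step stays open. So does whether nitro would give the same step elsewhere on the ring.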